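This account rests on a few compounds, and the source may have more. Where it says the series, first, only, none or still open, it means among the compounds named here.

In a functional assay on HepG2 cells (Homo sapiens) for antiproliferative activity, read by sulforhodamine B assay, with a stated time of 48 h (on this read-out higher numbers stand for weaker inhibition and lower numbers for stronger inhibition), compound 1 `COc1ccc(C(=O)/C=C/c2ccccc2-c2ccc(F)nc2)cc1OC` gives 17000 nM and compound 2 `O=C(/C=C/c1ccccc1-c1ccc(F)nc1)c1cccc(O)c1` gives 6400 nM which is the lower of the two numbers, by a gap beyond the usual scatter. Compound 3 `COc1ccc(C(=O)/C=C/c2ccccc2-c2ccc(F)nc2)cc1O` is still unmeasured and carries one change from compound 2: methoxy in place of hydrogen on an aromatic carbon, ortho to a hydroxy group and para to a large group (methoxy in place of hydrogen on an aromatic carbon). Among the measured compounds shown here, no measured step shows this change, so only a small shift toward stronger inhibition in this assay is expected, and the estimated 1.3-fold lower number from compound 2 to compound 3 (0.11 log units; within the scatter) stays within the scatter. The estimated value for compound 3 is 5000 nM with an expected range from 1500 nM to 16000 nM on this read-out.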

Compound 3, half-maximal inhibitory concentration: 1800 nM
Compound 3: the middle estimate sits 2.8-fold (0.44 log units) above what was measured, and the stated range covers the measured number.
By their numbers in this assay, from the lowest: compound 3; then compound 2; then compound 1.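

In this assay the carbon ortho to a hydroxy group and para to a large group proves able to change the read-out: methoxy in place of hydrogen there gives a 3.6-fold lower number from compound 2 to compound 3 (0.55 log units; beyond the scatter) in a step beyond the scatter. The hydroxy group matters too, since hydrogen in place of methyl on that oxygen gives a 9.4-fold lower number from compound 1 to compound 3 (0.98 log units; beyond the scatter) and so a free hydroxy group outperforms its methoxy form here. Nothing available explains either step. Going by these compounds, whether ethoxy or chlorine would match methoxy at this carbon remains open. So does whether an amine could replace the hydroxy group.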